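Swapping a fluoro for a triazole on a receptor agonist

This account rests on a few compounds, and the source may have more. Where it says the series, first, only, none or still open, it means among the compounds named here.

Measured compounds:
Compound 1 `CC1(OC(=O)N2CC3COCC(C2)C3Oc2ncnc(Oc3ccccc3F)c2F)CC1`: 114%
Compound 2 `CC1(OC(=O)N2CC3COCC(C2)C3Oc2ncnc(Nc3ccc(F)cc3F)c2F)CC1`: 94%
Compound 3 `N#Cc1ccc(Oc2ncnc(OC3C4COCC3CN(c3ncc(F)cn3)C4)c2C2CC2)c(Cl)c1`: 56%

In a functional assay on HEK293 cells for agonist activity at Glucose-dependent insulinotropic receptor (Homo sapiens), read by cAMP accumulation, with a stated time of 30 min (a higher number here means a larger maximal response, a lower number a smaller maximal response), compound 1 gives 114%, compound 2 gives 94% and compound 3 gives 56%. Compound 2 stands second highest of the three; the step of a number 20 percentage points lower from compound 1 to compound 2 (beyond the scatter) is beyond the scatter, and compound 3 lies well below it.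

Compound 4 `CC1(OC(=O)N2CC3COCC(C2)C3Oc2ncnc(Nc3ccc(-n4cncn4)cc3F)c2F)CC1` is made from compound 2 by one change, (1H-1,2,4-triazol-1-yl in place of fluoro on an aromatic carbon). For the measured compounds named here, the only measured step, from compound 1 to compound 2, exchanges an aryl ether for an aryl amine, which is a different kind of change and does not bear directly on this one. Compound 3 shares no single-point relation with either. Going by the values given here, with no step that speaks to a change of this type, the expectation is that the step of a number 4 percentage points lower from compound 2 to compound 4 (within the scatter) stays close to the scatter. For compound 4 a value of 90% is estimated, expected to fall between 70% and 110%.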

Compound 4, largest response reached (reported as percent of maximum), in percent of the reference or control that the assay uses: 73%
For compound 4 the middle estimate is 17 percentage points above the measured one, and the stated range covers the measured number.
By their numbers in this assay, from the lowest: compound 3; then compound 4; then compound 2; then compound 1.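

In this assay the place para to a large group and meta to a fluoro group proves sensitive to what sits on it: 1H-1,2,4-triazol-1-yl in place of fluoro gives a step of a number 21 percentage points lower from compound 2 to compound 4 (beyond the scatter) that lies beyond the scatter. A larger group carrying a five-membered aromatic ring can stand at this place, and compound 4 still reaches 73%, but the maximal response is smaller than with fluoro. Nothing measured here accounts for this drop.

Still open, as far as these compounds go, is where a small methoxy group or a different ring, such as 1H-pyrazol-1-yl, would fall relative to fluoro and the triazole at this place. Also open, from the compounds shown here alone, is whether the same exchange would produce a similar step in a compound with an aryl ether link, such as compound 1.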